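The source may hold more compounds than are shown below. What is called first, only, known or untested is meant among the compounds shown, and "the series" means these compounds.

Compound 2, with the structure `O=C(O)COc1ccc(F)cc1C1CCCCC1`, stands second highest among the three numbers measured in an assay on CHO cells for displacement of a labelled ligand from prostaglandin D2 receptor 2 (Homo sapiens); a higher number here means a weaker inhibitor, a lower number a stronger inhibitor: it gives 446 nM. Compound 1, with the structure `CC1(c2cc(Cl)ccc2OCC(=O)O)CCCCC1`, gives 90 nM in this assay, a lower number than compound 2 by a margin beyond the usual scatter. Compound 3, with the structure `O=C(O)CCCOc1ccc(Cl)cc1C1CCCCC1`, gives 1990 nM in this assay, a higher number than compound 2, again by a margin beyond the scatter. Among the measured compounds shown here, no pair of these three differs in only one place, so their gaps cannot be read as single steps.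

Compound 4, with the structure `O=C(O)COc1ccc(-c2ccc(F)cc2)cc1C1CCCCC1`, has not yet been measured. It differs from compound 2 in one place: 4-fluorophenyl in place of fluoro on an aromatic carbon. For the measured compounds named here, no measured pair shows what such a change does in this assay, so the expectation rests on the spread of the three numbers given so far. The step from compound 2 to compound 4 is expected to be a 1.8-fold lower number from compound 2 to compound 4 (0.25 log units; within the scatter), a modest move toward a lower number that may not clear the scatter. On that basis compound 4 is estimated to give 250 nM in this assay, with a range from 60 nM to 1200 nM.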

Compound 4, inhibition constant: 99 nM
For compound 4 the middle estimate is 2.5-fold (0.40 log units) above the measured one, within the range that was stated.
By their numbers in this assay, from the lowest: compounds 1 and 4 (each within the scatter of the next); then compound 2; then compound 3.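

The aromatic carbon meta to the cyclohexyl group and para to the carboxymethoxy group takes far more than a lone fluoro: in this assay, 4-fluorophenyl, with 7 heavy atoms, in place of fluoro, with 1 heavy atom, gives a 4.5-fold lower number from compound 2 to compound 4 (0.65 log units; beyond the scatter), a change beyond the scatter. Among the compounds shown here, none of the earlier compounds differed in only one place, so this is the first change that can be read as a single step, and it shows that a whole six-membered aromatic ring of carbon only can enter at this carbon with no loss, and indeed with a lower number. No measurement at hand bears on why the number falls.

It stays open whether the lower number goes with the ring itself or with its fluorine, as the compounds shown include neither a plain phenyl, a 4-methoxyphenyl nor a pyridine ring at this carbon. Also open, on these data alone, is whether the same change would give a similar step on the core of compound 1 or with the longer acid chain of compound 3.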